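From ethyl to cyano in a series at its limit

The compounds below may be only part of what the source reports. "The series", "measured", "known", "first", "only" and "open" are said of these compounds alone.

Measured in a functional assay on SK-MEL-28 cells (Homo sapiens) for inhibition, read by MTT assay, with a stated time of 48 h; on this read-out lower numbers stand for stronger inhibition and higher numbers for weaker inhibition:
compound 1 `CCc1ccc(-c2nc3ccccn3c2Sc2ccccc2)cc1`: > 100000 nM
compound 2 `Cc1ccc(-c2nc3ccccn3c2Sc2ccccc2)cc1`: > 100000 nM
compound 3 `c1ccc(Sc2c(-c3cccc4ccccc34)nc3ccccn23)cc1`: > 100000 nM

Each entry is a limit of the assay and not a number. Compound 1 stands only at its limit of > 100000 nM. Among the compounds with values here, the whole series so far sits at the limit of > 100000 nM in this assay, at which 3 of the 3 values shown sit, so no measured number is available as a starting point.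

Compound 4 `N#Cc1ccc(-c2nc3ccccn3c2Sc2ccccc2)cc1` has not yet been measured. It carries cyano in place of ethyl on an aromatic carbon of a six-membered aromatic ring of carbon only, para to a large group, the change from 4-ethylphenyl to 4-cyanophenyl: cyano in place of ethyl on an aromatic carbon.

Within the data shown here, the one measured step bearing on this change is a step that the two limits leave unreadable from compound 1 to compound 2, which alters the same ethyl group. That step has no readable size, so it offers neither a size nor a direction to carry over. No step beyond the scatter can therefore be forecast in this assay, and compound 4 is expected to stay near the same limit, most likely reported only as a limit. The expected step is a number no higher from compound 1 to compound 4 (the limit leaves the size open). The estimate for compound 4 is 100000 nM, with an expected range of 30000 nM to 300000 nM.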

Compound 4, half-maximal inhibitory concentration: 67500 nM
Beside the measured number, compound 4's estimate is 1.5-fold (0.17 log units) above it; measured number inside the range.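

In this assay, within the data shown here, compound 4 gives 67500 nM, the first readable number, so this position, on an aromatic carbon of a six-membered aromatic ring of carbon only, para to a large group, now has a measured value to work from. As far as these compounds go, the change to cyano reads as an at least 1.4-fold lower number from compound 1 to compound 4 (0.17 log units; that floor lies within the scatter), and as an at least 1.4-fold lower number from compound 2 to compound 4 (0.17 log units; that floor lies within the scatter), so on these floors alone neither step can be called real, and their full size remains unknown. The step between the ethyl and methyl compounds cannot be read, and compound 4 is the only entry that is a number and not a limit: the limit of > 100000 nM in this assay, at which 3 of the 4 values shown sit.

From the compounds shown here alone, whether another group at this position, such as an amine, a carboxylic acid or a longer chain, would move the number beyond the scatter from compound 4 remains open. Also open, going by these compounds, is what a change elsewhere on the shared core would do, since compound 1, compound 2 and compound 4 differ only at this one position.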